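A few compounds are considered here, and "the series" means these few. Any claim that something is new, unique, unknown or untested is made for them only; others in the source may bear on it.

Of the compounds shown here, three have been measured in a functional assay on DU-145 cells (Homo sapiens) for cytotoxicity, read by MTT assay; a higher number here means a weaker inhibitor, a lower number a stronger inhibitor. Compound 1 `CCC(C)(O)CC(=O)O[C@H](CC=C(C)C)C1=CC(=O)c2c(O)ccc(O)c2C1=O` gives 16000 nM in this assay; compound 2 `CC[C@@](C)(O)CC(=O)O[C@H](CC=C(C)C)C1=CC(=O)c2c(O)ccc(O)c2C1=O` gives 12700 nM; compound 3 `COC(C)CO[C@H](CC=C(C)C)C1=CC(=O)c2c(O)ccc(O)c2C1=O` gives 16600 nM. Behind the step of a 1.3-fold lower number from compound 1 to compound 2 (0.10 log units; within the scatter) stands (the fact that one of compounds 1 and 2 is drawn with a defined configuration and the other without, at the place where they differ). Compound 3 has the highest of the three numbers, but its steps to the other two are within the scatter, as the steps of a 1.0-fold higher number from compound 1 to compound 3 (0.02 log units; within the scatter) and a 1.3-fold higher number from compound 2 to compound 3 (0.12 log units; within the scatter) show.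

Compound 4 `CC(C)=CC[C@@H](OC(=O)C1CCCCO1)C1=CC(=O)c2c(O)ccc(O)c2C1=O` is not yet measured. It differs from compound 3 at one place: (oxan-2-yl)carbonyl in place of 2-methoxypropyl on an oxygen on a saturated carbon. Within the data shown here, the steps that bear on this change are those from compound 1 and compound 2 to compound 3, where (2-hydroxy-2-methylbutyl)carbonyl gave way to 2-methoxypropyl on the same oxygen. The change to compound 4 runs the other way, bringing a carbonyl back onto that oxygen as (oxan-2-yl)carbonyl, and since a 1.0-fold higher number from compound 1 to compound 3 (0.02 log units; within the scatter) and a 1.3-fold higher number from compound 2 to compound 3 (0.12 log units; within the scatter) both lay within the scatter, no step beyond the scatter is expected here either, in neither direction. The expected step is a 1.1-fold lower number from compound 3 to compound 4 (0.04 log units; within the scatter). Compound 4 is therefore estimated at 15000 nM in this assay, with a range from 7000 nM to 32000 nM.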

Compound 4, half-maximal inhibitory concentration: 24700 nM
Compound 4: middle estimate off by 1.6-fold (0.22 log units), on the low side; measured number inside the range.
By their numbers in this assay, from the lowest: compounds 2, 1, 3 and 4 (each within the scatter of the next).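

In this assay, an ester carrying a ring is now tolerated on an oxygen on a saturated carbon: a 1.5-fold higher number from compound 3 to compound 4 (0.17 log units; within the scatter), where (oxan-2-yl)carbonyl, with its six-membered non-aromatic ring, replaces the open-chain 2-methoxypropyl. Direct comparison of the two esters gives the same reading, with oxan-2-yl in place of 2-hydroxy-2-methylbutyl on a carbonyl carbon giving a 1.5-fold higher number from compound 1 to compound 4 (0.19 log units; within the scatter) and a 1.9-fold higher number from compound 2 to compound 4 (0.29 log units; within the scatter), so this position has now taken an open-chain ether, open-chain esters with a hydroxyl group and a cyclic ester without any step beyond the scatter. Nothing measured here explains these small steps, and the only recorded observation concerns the drawn configuration of compounds 1 and 2, not the group exchanged in compound 4.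

On these data alone, whether any group on this oxygen can move the number beyond the scatter remains open, for example an amine, a carboxylic acid or a longer chain ending in a phenyl ring. The compounds shown also leave open whether a free hydroxyl on the same oxygen, with no ester or ether group, would read differently from compounds 1 to 4 in this assay.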